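A hydroxy group added to compound 2

The compounds below may be only part of what the source reports. "The series", "measured", "known", "first", "only" and "open" are said of these compounds alone.

Among the compounds with values here, in a functional assay on COLO 205 cells (Homo sapiens) for inhibition, read by sulforhodamine B assay (on this read-out lower numbers stand for stronger inhibition of growth and higher numbers for weaker inhibition of growth), compound 2 `CN(C)c1ccc(-c2ccc(-c3ccc(-c4nc5ccccc5[nH]4)cc3)cc2)cc1` gives 100000 nM and sits level with compound 1 `FC(F)(F)Oc1ccc(-c2ccc(-c3ccc(-c4nc5ccccc5[nH]4)cc3)cc2)cc1` at 100000 nM as the highest numbers so far, while compound 3 `COc1ccc(-c2ccc(-c3ccc(-c4nc5ccccc5[nH]4)cc3)cc2)cc1OC` comes in at 41200 nM by comparison. Compound 4 `CN(C)c1ccc(-c2ccc(-c3ccc(-c4nc5c(O)cccc5[nH]4)cc3)cc2)cc1` carries one change from compound 2, namely hydroxy in place of hydrogen on an aromatic carbon in the form of hydroxy in place of hydrogen on an aromatic carbon. Two measured steps changed a different group, so they bear only loosely here: no change at the digits printed from compound 1 to compound 2 (within the scatter) and then a 2.4-fold lower number from compound 2 to compound 3 (0.39 log units; beyond the scatter) as the largest seen. In this assay, within the data shown here, only a modest move toward a lower number is therefore expected, with no measured step at this place to confirm it. The expected size is a 2.2-fold lower number from compound 2 to compound 4 (0.35 log units; beyond the scatter) in this estimate. For compound 4 the estimated value is 45000 nM with a range of 10000 nM to 100000 nM around it.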

Compound 4, concentration for 50% growth inhibition: 6320 nM
For compound 4 the middle estimate is 7.1-fold (0.85 log units) above the measured one; the measured number lies below the stated range.
By their numbers in this assay, from the lowest: compound 4; then compound 3; then compounds 1 and 2 (each within the scatter of the next).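

In this assay, within the data shown here, hydroxy in place of hydrogen on the benzimidazole part gives a 16-fold lower number from compound 2 to compound 4 (1.20 log units; beyond the scatter) and shows that this ring, unchanged in the earlier compounds, has a strong hold on the growth-inhibition number. The earlier steps shown here changed only the group on the far phenyl ring, and neither moved the number this much. Nothing available here explains the gain.

Going by these compounds, whether a methoxy or an amine at the same place would do as well remains open. So does whether the hydroxy would bring a similar gain to compound 3 or to compound 1.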